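The compounds below may be only part of what the source reports. "The series", "measured", "known", "first", "only" and "open" are said of these compounds alone.

Measured compounds:
compound 1 `CC[C@H](C)[C@H](NC(=O)c1cccc(Cn2ccnc2)c1)C(=O)Nc1nccs1`, 42000 nM in an assay on HEK293 cells for displacement of a labelled ligand from Type-2 angiotensin II receptor (Homo sapiens); on this read-out higher numbers stand for weaker inhibition and lower numbers for stronger inhibition
compound 2 `CC[C@H](C)[C@H](NC(=O)c1cccc(Cn2ccnc2)c1)C(=O)NNS(=O)(=O)c1ccc(C)cc1`, 29000 nM
compound 3 `CC[C@H](C)[C@H](NC(=O)c1cccc(Cn2ccnc2)c1)C(=O)NC#N`, "not determined" (no result reported)

The three measured compounds share one core and differ only at the terminal amide. In this assay compound 1 gives 42000 nM and compound 2 gives 29000 nM; for compound 3 no number was reported. Going by the values given here, compound 2 carries the lowest of the two numbers, but the only step to it, a 1.4-fold lower number from compound 1 to compound 2 (0.16 log units; within the scatter), stays within the scatter, so neither compound can be called the stronger.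

Compound 4 `CC[C@H](C)[C@H](NC(=O)c1cccc(Cn2ccnc2)c1)C(=O)NNC(=O)OC(C)(C)C` is the next point. It differs from compound 2 by tert-butoxycarbonyl in place of (4-methylphenyl)sulfonyl on an amine nitrogen. No measured step bears on this exchange directly; the one step shown, a 1.4-fold lower number from compound 1 to compound 2 (0.16 log units; within the scatter), concerns a different replacement on the amide-type nitrogen and was itself within the scatter. With both measured compounds weak and close to each other, compound 4 is expected to stay in the same region, with an estimated change of a 1.2-fold higher number from compound 2 to compound 4 (0.08 log units; within the scatter) that lies within the scatter. The value of compound 4 is therefore estimated at 35000 nM, with a range from 15000 nM to 90000 nM.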

Compound 4, inhibition constant: > 100000 nM
Compound 4: only a limit was reported (the forecaster's own chance of this, stated with the estimate: 25%); at least 2.8-fold (0.45 log units) between middle value and limit.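

Replacing (4-methylphenyl)sulfonyl with tert-butoxycarbonyl on an amine nitrogen gives an at least 3.4-fold higher number from compound 2 to compound 4 (0.53 log units; beyond the scatter) and so produces a difference beyond the scatter, which the earlier pair of numbers did not show. Set against the 1,3-thiazol-2-yl amide, (tert-butoxycarbonyl)amino gives an at least 2.3-fold higher number from compound 1 to compound 4 (0.37 log units; beyond the scatter) as well, so the group on this amide-type nitrogen does affect the read-out. Going by these compounds, the result for compound 4 in this assay is only a limit, so the true size of both steps stays unknown: the limit of > 100000 nM in this assay, at which 1 of the 4 values shown sits.

With no number for compound 3, the nitrile-bearing amide cannot be compared with the others. On these data alone, it also remains open whether the change at this position follows the sulfonyl group or the aromatic ring, which a phenylacetyl or a methanesulfonyl group on the same amine nitrogen would help to separate.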